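Swapping a Methyl for a Fluorophenyl on the Ring Amine

This account rests on a few compounds, and the source may have more. Where it says the series, first, only, none or still open, it means among the compounds named here.

Two compounds set the scene. Compound 1 `O=C1NC(c2ccccc2)(c2ccccc2)C(=O)N1CN1CCN(c2ccccc2)CC1` and compound 2 `CC(C)C1(C(C)C)NC(=O)N(CN2CCN(C)CC2)C1=O` were both tested in a functional assay on the whole organism (strain CD1) with Mus musculus as the target, in the maximal electroshock model, with a stated time of 0.5 h; on this read-out lower numbers stand for an effect already at smaller amounts and higher numbers for an effect only at larger amounts of compound. In this assay compound 1 reaches its minimum effective dose at 300 mg/kg. In this assay compound 2 gives 300 mg/kg. Compound 2 thus stands level with compound 1 at the digits shown; no step between the two has been worked out, and the two values only show that neither compound stands apart from the other within the usual scatter of measurements of this kind.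

Compound 3 `CC(C)C1(C(C)C)NC(=O)N(CN2CCN(c3ccccc3F)CC2)C1=O` has not yet been measured. It differs from compound 2 in one place: 2-fluorophenyl in place of methyl on an amine nitrogen in a ring. Compound 1 also carries an aromatic ring on an amine nitrogen in a ring and gives 300 mg/kg in this assay, which offers no sign that such a ring moves the dose. Compound 3 is therefore expected to show a step from compound 2 of no change at the digits printed from compound 2 to compound 3 (within the scatter), that is, none beyond the scatter. The estimate for compound 3 is 300 mg/kg, with a range from 100 mg/kg to 600 mg/kg, and the assay may report only a limit.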

Compound 3, minimum effective dose: 100 mg/kg
The estimate for compound 3 lay 3.0-fold (0.48 log units) above the measured number; low and high end bracket the measured number.
By their numbers in this assay, from the lowest: compound 3; then compounds 1 and 2 (each within the scatter of the next).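

Within the data shown here, the measurement in this assay gives a 3.0-fold lower number from compound 2 to compound 3 (0.48 log units; beyond the scatter) when 2-fluorophenyl takes the place of methyl on an amine nitrogen in a ring, and this is the only step in the set so far. It shows that this position responds to what it carries: the entering group, with seven heavy atoms against the single carbon of methyl and a six-membered aromatic ring, goes with an effect at a smaller dose. Compound 1 and compound 2 differ in more than one place, so their level values could not show this. Nothing measured here accounts for the step.

The compounds shown leave open whether the aromatic ring alone is enough or whether the fluorine also contributes, a question that a plain phenyl on the core of compound 2 would address. Also open, on these data alone, is how other groups would fare on this nitrogen, such as a benzyl group, a pyridine ring or a longer alkyl chain, and whether the same change would count on the core of compound 1.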